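A few compounds are considered here, and "the series" means these few. Any claim that something is new, unique, unknown or untested is made for them only; others in the source may bear on it.

The measured compounds in a functional assay on MCF7 cells (Homo sapiens) for cytotoxicity, read by MTT assay, with a stated time of 72 h, tested at 100 uM (on this read-out lower numbers stand for less inhibition of growth and higher numbers for more inhibition of growth at the one concentration tested), are these:

Compound 1, `N/C(=N\NC(=S)N1CCSCC1)c1ccccn1`, gives 72.4%.
Compound 2, `Cc1ccnc(/C(N)=N/NC(=S)N2CCCCCC2)c1`, gives 65.4%.
Compound 3, `N/C(=N\NC(=S)N1CCOCC1)c1ccc(F)cn1`, gives 61.5%.

Compound 3 stands lowest of the three numbers. Its nearest neighbour is compound 2, whose number is higher by an amount that lies within the scatter of this assay, so nothing can be read into the order of those two. Compound 1 is furthest away, with a number that is higher by more than the scatter. Among the measured compounds no pair differs in one place only, so no single structural change has yet been tied to a change in growth inhibition.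

The step to be taken now leads from compound 3 to compound 4, `N/C(=N\NC(=S)N1CCOCC1)c1ccccn1`. The difference between the two is small: hydrogen in place of fluoro on an aromatic carbon. Among the compounds with values here, nothing in the measured set speaks to what this change does, since no step involving a fluoro group is available. Compound 4 is therefore expected to land near compound 3, at 63%, with a plausible range from 50% to 76%. The step this estimate implies, a number 1.5 percentage points higher from compound 3 to compound 4 (within the scatter), is expected to stay within the scatter of repeated measurements, in no particular direction.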

Compound 4, percent growth inhibition at one concentration: 81.6%
For compound 4 the middle estimate is 18.6 percentage points below the measured one, and the stated range ends below it.
By their numbers in this assay, from the lowest: compounds 3, 2, 1 and 4 (each within the scatter of the next, the first and the last beyond it).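

In this assay, within the data shown here, hydrogen in place of fluoro on an aromatic carbon, two atoms from the ring nitrogen and para to a large group, comes with a number 20.1 percentage points higher from compound 3 to compound 4 (beyond the scatter) and is the first single change in this set tied to a difference beyond the scatter, so this position is not indifferent to the group it carries. The other end of the molecule gives no such signal here: morpholin-4-yl in place of thiomorpholin-4-yl on a thiocarbonyl carbon comes with a number 9.2 percentage points higher from compound 1 to compound 4 (within the scatter) and so cannot be told apart from repeated measurement. No accompanying measurement offers an explanation for the fluoro step.

The compounds shown leave open whether the lower number in compound 3 is particular to fluoro, or whether chloro, methoxy or an amine at the same aromatic carbon would also give a number well apart from that of compound 4. They also leave open whether the same exchange of fluoro for hydrogen has a similar size when thiomorpholin-4-yl replaces morpholin-4-yl on the thiocarbonyl carbon.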